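The source may report more compounds than this note shows. Statements on the series, on what has been measured and on what is new or still open speak of the compounds shown alone.

Series notes, an in vitro assay on Sf21 cells for inhibition of high affinity 3',5'-cyclic-AMP phosphodiesterase 7A (Homo sapiens), read by scintillation proximity assay, with a stated time of 30 min; a higher number here means a weaker inhibitor, a lower number a stronger inhibitor. Within the data shown here, compound 1 `CCN(CC)c1ccc(NC(=O)c2cn(Cc3c(F)cccc3F)c3ccc(=O)[nH]c3c2=O)cc1` gives 46 nM in this assay, and compound 2 `NS(=O)(=O)c1ccc(NC(=O)c2cn(Cc3c(F)cccc3F)c3ccc(=O)[nH]c3c2=O)cc1` gives 34 nM; the one measured step, a 1.4-fold lower number from compound 1 to compound 2 (0.13 log units; within the scatter), concerns a group on the aryl amide and lies within the scatter. Compound 3 `COc1cc(NC(=O)c2cn(Cc3ccccc3F)c3ccc(=O)[nH]c3c2=O)cc(OC)c1OC` gives 206 nM, the highest of the three numbers, beyond the scatter from both compound 1 and compound 2. Compound 4 `COc1cc(NC(=O)c2cn(Cc3ccc(F)cc3)c3ccc(=O)[nH]c3c2=O)cc(OC)c1OC` is not yet measured. The change is 4-fluorophenyl in place of 2-fluorophenyl on a saturated chain carbon bound to an aromatic nitrogen. Among the measured compounds shown here, no measured step touches this part of the molecule, and compounds 1 and 2 carry a different benzyl group, so no direct precedent exists. A step in this assay no larger than the scatter is therefore expected, in no particular direction. The expected step from compound 3 to compound 4 is a 1.0-fold lower number from compound 3 to compound 4 (0.01 log units; within the scatter). Compound 4 is expected at 200 nM, with a range of 80 nM to 500 nM.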

Compound 4, half-maximal inhibitory concentration: 868 nM
The estimate for compound 4 lay 4.3-fold (0.64 log units) below the measured number, outside the stated range (above it).
By their numbers in this assay, from the lowest: compounds 2 and 1 (each within the scatter of the next); then compound 3; then compound 4.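

The step from 2-fluorobenzyl to 4-fluorobenzyl gives a 4.2-fold higher number from compound 3 to compound 4 (0.62 log units; beyond the scatter) in this assay. This position, on a saturated chain carbon bound to an aromatic nitrogen, therefore responds to where the fluorine sits, although the heavy-atom count and the hydrogen-bond donor and acceptor counts of the group stay the same. No measurement at hand accounts for this step.

Still open, as far as these compounds go, is how an unsubstituted benzyl, or chlorine or methoxy in place of the fluorine, would read here. From the compounds shown here alone, whether the step carries over to the diethylamino and sulfamoyl aryl amides also remains unknown.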